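This account rests on a few compounds, and the source may have more. Where it says the series, first, only, none or still open, it means among the compounds named here.

Working notes on the series. Compound 1 `CC(C)OC(=O)N1CCC(O[C@H]2CC[C@H](Oc3ccc(S(C)(=O)=O)nc3)CC2)CC1` gives 201 nM in a functional assay on isolated protein for agonist activity at Glucose-dependent insulinotropic receptor (Rattus norvegicus), read by HTRF and cAMP accumulation; a lower number here means that less compound is needed, a higher number that more compound is needed for the effect. Compound 2 `CC(C)(C)OC(=O)N1CCC(O[C@H]2CC[C@H](Oc3ccc(S(C)(=O)=O)nn3)CC2)CC1` gives 1160 nM in this assay. Compound 3 `CC(C)OC(=O)N1CCC(O[C@H]2CC[C@H](Oc3cnc(S(C)(=O)=O)cn3)CC2)CC1` gives 119 nM in this assay. Compound 3 has the lowest of the three numbers; its nearest neighbour is compound 1, and the step of a 1.7-fold lower number from compound 1 to compound 3 (0.23 log units; within the scatter) lies within the scatter, so these two are not separated. For the measured compounds named here, compound 2 stands furthest, with a number beyond the scatter above that of compound 3; compound 2 also differs from compound 3 in more than one place, so no single step is drawn from that pair.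

Compound 4 `CS(=O)(=O)c1cnc(O[C@H]2CC[C@H](OC3CCN(CC4(C(F)(F)F)CCC4)CC3)CC2)cn1` is not yet measured. It differs from compound 3 as follows: (1-(trifluoromethyl)cyclobutyl)methyl in place of isopropoxycarbonyl on an amine nitrogen in a ring. Going by the values given here, none of the measured steps touches this position; the one measured step, a 1.7-fold lower number from compound 1 to compound 3 (0.23 log units; within the scatter), concerns the aromatic group on the oxygen and says nothing about the substituent on the ring nitrogen. No direction is therefore expected with any confidence, and the range is kept wide. The estimate for compound 4 in this assay is 300 nM, between 60 nM and 1500 nM. This corresponds to an expected step of a 2.5-fold higher number from compound 3 to compound 4 (0.40 log units; beyond the scatter).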

Compound 4, half-maximal effective concentration: 80 nM
The estimate for compound 4 lay 3.8-fold (0.57 log units) above the measured number; measured number inside the range.
By their numbers in this assay, from the lowest: compounds 4, 3 and 1 (each within the scatter of the next, the first and the last beyond it); then compound 2.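

For the compounds shown here, the step at the amine nitrogen in the ring, a 1.5-fold lower number from compound 3 to compound 4 (0.17 log units; within the scatter), is the first reading at this position in this assay, and it does not separate the two compounds. At this position, then, the carbamate-type isopropoxycarbonyl group, which carries hydrogen-bond acceptors, and (1-(trifluoromethyl)cyclobutyl)methyl, which carries none, read alike on this shared core. Nothing measured here bears on why the two groups give such similar numbers.

Going by these compounds, it remains open whether a plain cyclobutylmethyl group without the trifluoromethyl, a benzyl group or a longer alkyl chain on this nitrogen would also read alike. Also open, on these data alone, is whether the same match holds with the 6-(methylsulfonyl)pyridin-3-yl group of compound 1 on the oxygen, since this single pair carries only the 5-(methylsulfonyl)pyrazin-2-yl group.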